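From 2-ethoxyethoxy to (4-cyanobenzyl)oxy

The source may hold more compounds than are shown below. What is called first, only, known or untested is meant among the compounds shown, and "the series" means these compounds.

In a functional assay on RAW264.7 cells (Mus musculus) for inhibition, read by Griess assay, with stated times of 1 h and 24 h (a lower number here means a stronger inhibitor, a higher number a weaker inhibitor), compound 1 (`COCCOc1ccc(C(O)C2OC(=O)c3c(OC)cc(OC)cc32)cc1`) gives > 10000 nM as a limit and not a number. From the compounds shown here alone, compound 2 (`CCOCCOc1ccc(C(O)C2OC(=O)c3c(OC)cc(OC)cc32)cc1`) gives > 10000 nM in this assay as a limit too, so its true position remains unknown. Within the data shown here, the one measured step, methyl in place of hydrogen on a saturated chain carbon bound to an oxygen on a saturated carbon, is a step that the two limits leave unreadable from compound 1 to compound 2 and offers no size to carry forward.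

Compound 3 (`COc1cc(OC)c2c(c1)C(C(O)c1ccc(OCc3ccc(C#N)cc3)cc1)OC2=O`) carries a different change: 4-cyanophenyl in place of ethoxymethyl on a saturated chain carbon bound to an oxygen on an aromatic ring with 4-cyanophenyl in place of ethoxymethyl on a saturated chain carbon bound to an oxygen on an aromatic ring. Among the measured compounds shown here, no measured step covers this exchange. Because of the limit of > 10000 nM in this assay, at which 2 of the 2 values shown sit, the expectation for compound 3 rests only on compound 2 and compound 1 sharing that limit, and a result close to it is expected in this assay with no firm direction. The estimated change is a number no higher from compound 2 to compound 3 (the limit leaves the size open) and may not be readable. For compound 3 the estimated value is 10000 nM with an expected range from 3000 nM to 30000 nM as the working span.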

Compound 3, half-maximal inhibitory concentration: 7360 nM
Compound 3: middle estimate off by 1.4-fold (0.13 log units), on the high side, within the range that was stated.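

In this assay, among these compounds, compound 3, with (4-cyanobenzyl)oxy in place of 2-ethoxyethoxy, gives 7360 nM, a number and not a limit, and so is the only one of the three compounds with a readable position at this site. Among the compounds shown here, the exchange reads as an at least 1.3-fold lower number from compound 2 to compound 3 (0.13 log units; that floor lies within the scatter), and the matching exchange from the shorter chain reads as an at least 1.3-fold lower number from compound 1 to compound 3 (0.13 log units; that floor lies within the scatter), so a change at this place can be tied to a number for the first time, though only as a floor that does not clear the scatter. The true size of either step stays unknown, as each rests on a limit: the limit of > 10000 nM in this assay, at which 2 of the 3 values shown sit.

From the compounds shown here alone, whether the measured value of compound 3 goes with the aromatic ring of the 4-cyanophenyl group or with its nitrile stays open, and a plain benzyl group in the same place would separate the two. Also open, going by these compounds, is whether a longer chain ending in an amine at this place keeps a measurable value in this assay or gives a limit again.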